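This account rests on a few compounds, and the source may have more. Where it says the series, first, only, none or still open, it means among the compounds named here.

Measured compounds:
compound 1 `CCCSC[C@H](NC(C)=O)C(=O)CCl`: in a functional assay on MOLT-3 cells (Homo sapiens) (a lower number here means a stronger inhibitor, a higher number a weaker inhibitor), compound 1 gives 8000 nM
compound 2 `CCCCCSC[C@H](NC(C)=O)C(=O)CCl`: compound 2 gives 5400 nM
compound 3 `CCCCCCCCCCCCCCCCCCCCSC[C@H](NC(C)=O)C(=O)CCl`: compound 3 gives only a limit of this assay, > 100000 nM

Compounds 1 and 2 differ by ethyl in place of hydrogen on a saturated chain carbon, three bonds along the chain from a sulfur, and the step is a 1.5-fold lower number from compound 1 to compound 2 (0.17 log units; within the scatter). Compound 4 `CCCCCCCCCCCCCCCCCCCCCCSC[C@H](NC(C)=O)C(=O)CCl` stands to compound 3 by ethyl in place of hydrogen on a saturated chain carbon, ten or more bonds along the chain from a sulfur. The difference between the two cores, compound 1 against compound 3, is not broken down here. The change to compound 4 is the same kind of change as that to compound 2, not the same: the two sit at different places along the chain from a sulfur, as the two differences above show. The step expected is a step that the limit leaves unreadable from compound 3 to compound 4, set beside a 1.5-fold lower number from compound 1 to compound 2 (0.17 log units; within the scatter), and it is expected to leave compound 4 at a limit because the limit of > 100000 nM in this assay, at which 1 of the 3 values shown sits, already holds compound 3. Compound 4 is expected in this assay at 200000 nM.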

Compound 4, half-maximal inhibitory concentration: > 100000 nM
Compound 4: no number, only a limit; the forecaster's own chance of this, stated with the estimate: 90%; the middle value is on the limit's open side.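

Compound 3 and compound 4 both sit at a limit in this assay, so no step between them can be read: the limit of > 100000 nM in this assay, at which 2 of the 4 values shown sit.

The compounds shown leave open how the number behaves at chain lengths between those of compound 2 and compound 3.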